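This account rests on a few compounds, and the source may have more. Where it says the series, first, only, none or still open, it means among the compounds named here.

Measured compounds:
- compound 1, `COc1cc(C(=O)c2sc(-c3ccc([N+](=O)[O-])cc3)cc2N)cc(OC)c1OC`: 110 nM
- compound 2, `COc1cc(C(=O)c2sc(-c3ccccc3)cc2N)cc(OC)c1OC`: 5.3 nM
- compound 3, `COc1cccc(-c2cc(N)c(C(=O)c3cc(OC)c(OC)c(OC)c3)s2)c1`: 17 nM

In a functional assay on MOLT-4 cells (Homo sapiens) for antiproliferative activity (on this read-out higher numbers stand for weaker inhibition and lower numbers for stronger inhibition), compound 1 gives the highest of the three numbers, so among these it is the weakest inhibitor; its nearest neighbour is compound 3, while compound 2 lies furthest away. Compound 4, `COc1cc(C(=O)c2sc(-c3ccc(C(F)(F)F)cc3)cc2N)cc(OC)c1OC`, has not yet been measured. It differs from compound 1 in one place: trifluoromethyl in place of nitro on an aromatic carbon. Two measured steps start from compound 1 and bear on this change. Taking the nitro away altogether gave a 21-fold lower number from compound 1 to compound 2 (1.32 log units; beyond the scatter), a large gain. Exchanging the whole 4-nitrophenyl for 3-methoxyphenyl gave a 6.5-fold lower number from compound 1 to compound 3 (0.81 log units; beyond the scatter), a more modest gain. Both steps show that losing the nitro lowers the number, but in compound 4 a trifluoromethyl takes the same position rather than a hydrogen, so the full gain seen for compound 2 is not taken for granted. A modest step downward in this assay is therefore expected for compound 4, estimated as a 3.1-fold lower number from compound 1 to compound 4 (0.50 log units; beyond the scatter). In this assay compound 4 is expected to give about 35 nM, within a range from 10 nM to 120 nM.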

Compound 4, half-maximal inhibitory concentration: 250 nM
Compound 4: middle estimate off by 7.1-fold (0.85 log units), on the low side; measured number outside the range, above it.
By their numbers in this assay, from the lowest: compound 2; then compound 3; then compound 1; then compound 4.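

In this assay, trifluoromethyl in place of nitro on this aromatic carbon gave a 2.3-fold higher number from compound 1 to compound 4 (0.36 log units; beyond the scatter), so losing the nitro does not by itself lower the number, as compound 2 alone had suggested. Measured against hydrogen, the trifluoromethyl gave a 47-fold higher number from compound 2 to compound 4 (1.67 log units; beyond the scatter), and exchanging the 3-methoxyphenyl for the 4-(trifluoromethyl)phenyl gave a 15-fold higher number from compound 3 to compound 4 (1.17 log units; beyond the scatter), so among these four compounds the gain belongs to the plain phenyl and the 3-methoxyphenyl, while the 4-nitrophenyl and 4-(trifluoromethyl)phenyl compounds both give much higher numbers. Nothing measured here accounts for why these two groups fall so far behind hydrogen.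

Nitro and trifluoromethyl are the only two groups shown at this place, so it stays open whether any group there can match hydrogen, and an amine, a hydroxyl or a single fluorine on the same carbon would help to show whether the rise holds for groups here in general. As far as these compounds go, it also stays open how a methoxy would behave at this place rather than where it stands in compound 3.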